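From Chloro to Methoxy at Compound 3

The source may report more compounds than this note shows. Statements on the series, on what has been measured and on what is new or still open speak of the compounds shown alone.

In an ADME assay on microsomes from liver (Mus musculus) for metabolic stability, read by LC-MS, using NADPH, with a stated time of 10 min, tested at 0.5 uM (a lower number here means that less of the compound is left, a higher number that more of the compound is left), compound 1 (`CC(=O)Nc1cc(-c2ccc(OC[C@@](C)(N)CC(C)C)c(F)c2)ccn1`) gives 70% and compound 2 (`CC(=O)Nc1cc(-c2cc(F)c(OC[C@@H](N)CC(C)C)c(F)c2)ccn1`) gives 90%. Compound 3 (`COC(=O)Nc1cc(-c2cnc(OC[C@@](C)(N)CC(C)C)c(Cl)c2)ccn1`) gives 65%, within the scatter of compound 1 and beyond the scatter below compound 2. Compound 4 (`COC(=O)Nc1cc(-c2cnc(OC[C@@](C)(N)CC(C)C)c(OC)c2)ccn1`) carries methoxy in place of chloro on an aromatic carbon, ortho to a (2-amino-2,4-dimethylpentyl)oxy group (methoxy in place of chloro on an aromatic carbon). Among the compounds with values here, no measured pair differs in one place only, so the data offer no direct guide to this change. A small downward step in this assay, not clearly beyond the scatter, is expected. The estimated change is a number 10 percentage points lower from compound 3 to compound 4 (within the scatter). For compound 4, the estimated value is 55%, with an expected range of 35% to 75%.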

Compound 4, percent of the compound remaining: 59%
For compound 4 the middle estimate is 4 percentage points below the measured one, and the stated range covers the measured number.
By their numbers in this assay, from the lowest: compounds 4, 3 and 1 (each within the scatter of the next, the first and the last beyond it); then compound 2.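

In this assay, methoxy in place of chloro on this aromatic carbon, ortho to a (2-amino-2,4-dimethylpentyl)oxy group and two atoms from the ring nitrogen, gives a number 6 percentage points lower from compound 3 to compound 4 (within the scatter). This is the first pair shown that differs in one place, and it shows that this exchange at this position does not move the percent remaining beyond the scatter. Nothing measured here speaks to a cause of this step.

Going by these compounds, whether ethoxy, an amine or a nitrile on this carbon would stay as close to compound 3 remains open. Also open, on these data alone, is whether the same exchange would give a similar step on the core of compound 1.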